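Replacing the pivaloyl group on the ring nitrogen with a cyclopentenone

This account rests on a few compounds, and the source may have more. Where it says the series, first, only, none or still open, it means among the compounds named here.

Compound 1 `C[C@@H](O[C@@H]1CN(C(=O)C(C)(C)C)C[C@H]1c1ccccc1)c1cc(C(F)(F)F)cc(C(F)(F)F)c1` is measured in an assay on CHO cells for displacement of a labelled ligand from Substance-P receptor (Homo sapiens) (a higher number here means a weaker inhibitor, a lower number a stronger inhibitor), where compound 1 gives 0.18 nM. This is the lowest of the three numbers. Compound 2 `C[C@@H](O[C@@H]1CN(C(=O)[C@@H]2COC(=O)N2)C[C@H]1c1ccc(F)cc1)c1cc(C(F)(F)F)cc(C(F)(F)F)c1` gives 0.34 nM in this assay, and compound 3 `C[C@@H](O[C@@H]1CN(C(=O)N(C)C)C[C@H]1c1ccc(F)cc1)c1cc(C(F)(F)F)cc(C(F)(F)F)c1` gives 0.38 nM. Compound 1 sits within the scatter of compound 2 but beyond it from compound 3. Going by the values given here, the only single-point step among the measured compounds is a 1.1-fold higher number from compound 2 to compound 3 (0.05 log units; within the scatter), so exchanging one group on the carbonyl carbon of the amide left the number essentially unchanged.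

Compound 4 `C[C@@H](O[C@@H]1CN(C2=CC(=O)CC2)C[C@H]1c1ccccc1)c1cc(C(F)(F)F)cc(C(F)(F)F)c1` differs from compound 1 by 3-oxocyclopent-1-en-1-yl in place of (tert-butyl)carbonyl on an amine nitrogen in a ring. This change is larger than the measured step, since the carbonyl that joins the substituent to the ring nitrogen is removed rather than re-decorated, so the measured step of compound 2 to compound 3 bears on it only loosely. Given that the one recorded change at this nitrogen substituent stayed within the scatter, compound 4 is expected to remain close to compound 1, with a step of a 2.5-fold higher number from compound 1 to compound 4 (0.40 log units; beyond the scatter) estimated. The estimate for compound 4 is 0.45 nM, with a range from 0.1 nM to 2 nM.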

Compound 4, half-maximal inhibitory concentration: 0.07 nM
For compound 4 the middle estimate is 6.4-fold (0.81 log units) above the measured one; the measured number lies below the stated range.
By their numbers in this assay, from the lowest: compound 4; then compounds 1, 2 and 3 (each within the scatter of the next, the first and the last beyond it).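

In this assay, the step of a 2.6-fold lower number from compound 1 to compound 4 (0.41 log units; beyond the scatter) shows that this position does not need a carbonyl bonded directly to the ring nitrogen, as compounds 1, 2 and 3 all have, to give a low number. With 3-oxocyclopent-1-en-1-yl on the amine nitrogen, the carbonyl belongs to a five-membered carbon ring, and the number goes down rather than up, a change of a different kind from the step within the scatter between compound 2 and compound 3. Nothing measured here accounts for this difference.

As far as these compounds go, whether the number depends on the ketone or on the ring double bond stays open, and a plain cyclopentyl or a cyclopentanone group on this nitrogen would separate the two. Also open, from the compounds shown here alone, is whether the 3-oxocyclopent-1-en-1-yl group would have the same effect alongside the fluorophenyl group of compounds 2 and 3.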